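Lauroyl glutamyl amides: restoring a carboxy on the distal unit

A few compounds are considered here, and "the series" means these few. Any claim that something is new, unique, unknown or untested is made for them only; others in the source may bear on it.

Measured in a functional assay on HEK293 cells for agonist activity at Nucleotide-binding oligomerization domain-containing protein 1 (Homo sapiens), read by spectrophotometry; a lower number here means that less compound is needed, a higher number that more compound is needed for the effect:
compound 1, `CCCCCCCCCCCNC(=O)[C@H](N)CCC(=O)NC(CCCC(N)C(=O)O)C(=O)O` — 0.826 nM
compound 2, `CCCCCCCCCCCC(=O)N[C@H](CCC(=O)NC(CCCC(N)C(=O)OCC)C(=O)OCC)C(=O)O` — 0.145 nM
compound 3, `CCCCCCCCCCCC(=O)N[C@H](CCC(=O)NCCCCCN)C(=O)O` — > 100 nM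

Compound 1 and compound 2 both carry a distal unit with two carboxy-type ends, free in compound 1 and as ethyl esters in compound 2, and both give values well below the limit of this assay. Compound 3 keeps the lauroyl glutamyl part but ends in a plain 5-aminopentyl chain. For compound 3 this assay reports only a limit, > 100 nM, so its position among the measured values is known only as lying at that limit (the limit of > 100 nM in this assay, at which 1 of the 3 values shown sits).

Compound 4, `CCCCCCCCCCCC(=O)N[C@H](CCC(=O)N[C@H](CCCCN)C(=O)O)C(=O)O`, differs from compound 3 by one change: carboxy in place of hydrogen on a saturated chain carbon bound to an amide-type nitrogen and a saturated chain carbon. The distal unit thus becomes an amino acid again, closer in kind to the unit in compound 1, which differs further by a second carboxy and a second amino group.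

Among the measured compounds shown here, no measured pair shows this single change, so its size is an expectation only. Compound 3 sits at the limit (the limit of > 100 nM in this assay, at which 1 of the 3 values shown sits). Compound 1, with its fuller distal unit, gives 0.826 nM. On that basis the step is expected to run toward lower values and beyond the scatter. For compound 4 the expected value in this assay is 30 nM, with a range from 3 nM to 300 nM, an expected step of an at least 3.3-fold lower number from compound 3 to compound 4 (0.52 log units; beyond the scatter).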

Compound 4, half-maximal effective concentration: > 100 nM
Compound 4: a limit, no number; the forecaster's own chance of this, stated with the estimate: 25%; middle value at least 3.3-fold (0.52 log units) away from the limit.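

In this assay compound 4 gives > 100 nM, a limit and not a number. Compound 3 also stands at a limit, so no step can be read between compound 3 and compound 4. The compounds shown leave open whether carboxy in place of hydrogen shifts the value at all, and which part of the fuller distal unit in compound 1 goes with its measured value.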